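Oxolan-3-yl in Place of 4-Methoxycyclohexyl on the Amide

This account rests on a few compounds, and the source may have more. Where it says the series, first, only, none or still open, it means among the compounds named here.

Compound 1 `CCN(CC)S(=O)(=O)c1ccc(S(=O)(=O)N2CCC[C@@H](C(=O)N[C@H]3CC[C@H](OC)CC3)C2)cc1`: 1350 nM
Compound 2 `CCN(CC)S(=O)(=O)c1ccc(S(=O)(=O)N2CCC[C@@H](C(=O)NC3COC3)C2)cc1`: 2340 nM
Compound 3 `CCN(CC)S(=O)(=O)c1ccc(S(=O)(=O)N2CCC[C@@H](C(=O)NC3CCOCC3)C2)cc1`: 3770 nM

These three compounds share one core and differ only in the group carried on an amide-type nitrogen. In a functional assay on MIA PaCa-2 cells (Homo sapiens) for inhibition, read by MTT assay, with a stated time of 7 days (on this read-out lower numbers stand for stronger inhibition and higher numbers for weaker inhibition), compound 1 gives the lowest of the three numbers. Compound 4 `CCN(CC)S(=O)(=O)c1ccc(S(=O)(=O)N2CCC[C@@H](C(=O)N[C@@H]3CCOC3)C2)cc1` carries oxolan-3-yl in place of 4-methoxycyclohexyl on an amide-type nitrogen. Two measured steps start from the same compound and change the same position: a 1.7-fold higher number from compound 1 to compound 2 (0.24 log units; within the scatter), and a 2.8-fold higher number from compound 1 to compound 3 (0.45 log units; beyond the scatter). Both ring replacements gave higher numbers, one within the scatter and one modestly beyond it. Compound 4 brings in another non-aromatic ring with 1 hetero atom, so a comparable shift toward higher numbers is expected, a 2.0-fold higher number from compound 1 to compound 4 (0.30 log units; within the scatter). Compound 4 is estimated at 2700 nM, within 1400 nM to 5500 nM.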

Compound 4, half-maximal inhibitory concentration: 750 nM
Estimate against measurement, compound 4: 3.6-fold (0.56 log units) above, outside the stated range (below it).
By their numbers in this assay, from the lowest: compounds 4, 1, 2 and 3 (each within the scatter of the next, the first and the last beyond it).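

In this assay a ring replacement at this amide-type nitrogen need not move the number, since oxolan-3-yl gives a 1.8-fold lower number from compound 1 to compound 4 (0.26 log units; within the scatter) despite being the smaller group. The choice among the oxygen rings does matter, with a 5.0-fold lower number from compound 3 to compound 4 (0.70 log units; beyond the scatter) and a 3.1-fold lower number from compound 2 to compound 4 (0.49 log units; beyond the scatter) both showing oxolan-3-yl apart from the other two. The shift toward higher numbers seen with those two rings therefore does not extend to every such ring.

Still open, on these data alone, is how an amine such as piperidin-4-yl or an open chain such as 2-methoxyethyl would compare here. No evidence is available to explain these differences.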